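Swapping a sulfonamide for an amide on a shared core

The compounds below may be only part of what the source reports. "The series", "measured", "known", "first", "only" and "open" are said of these compounds alone.

Of the compounds shown here, three on one core have been measured in a physicochemical assay for lipophilicity, at pH 7.4; on this read-out lower numbers stand for lower lipophilicity and higher numbers for higher lipophilicity. Compound 1 `COc1ccc(-c2cc(-c3cccc(S(C)(=O)=O)c3)cnc2N)cn1` gives 2.3 in this assay, and compound 3 `COc1ccc(-c2cc(-c3cccc(C(N)=O)c3)cnc2N)cn1` gives 1.7. The change between them is a number 0.60 log units lower from compound 1 to compound 3 (beyond the scatter). Compound 2 `CNS(=O)(=O)c1ccc(-c2cnc(N)c(-c3ccc(OC)nc3)c2)cc1` gives 2.2 in this assay. Its value and that of compound 1 lie within the scatter of each other, so no order between the two can be claimed, while compound 3 sits lower than compound 2 by more than the scatter.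

The next compound, compound 4 `CNC(=O)c1ccc(-c2cnc(N)c(-c3ccc(OC)nc3)c2)cc1`, is not yet measured. Compared with compound 2, the change is methylcarbamoyl in place of methylsulfamoyl on an aromatic carbon. Within the data shown here, one measured step bears on it: the exchange of methylsulfonyl for carbamoyl from compound 1 to compound 3, which gave a number 0.60 log units lower from compound 1 to compound 3 (beyond the scatter). The present change likewise replaces a sulfur-centred group with a carbon-centred amide on the same aromatic carbon, so a downward step of about that size is expected, as a number 0.60 log units lower from compound 2 to compound 4 (beyond the scatter), with no reason in the data to expect a reversal. Compound 4 is therefore estimated at 1.6 in this assay, with a range from 1.2 to 2.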

Compound 4, distribution coefficient: 1.8
For compound 4 the middle estimate is 0.20 log units below the measured one; the measured number falls inside the stated range.
By their numbers in this assay, from the lowest: compounds 3 and 4 (each within the scatter of the next); then compounds 2 and 1 (each within the scatter of the next).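

In this assay, the exchange of a sulfur-centred group for an amide has now lowered the number on a second pair of compounds, giving a number 0.40 log units lower from compound 2 to compound 4 (beyond the scatter). The direction seen in the one earlier step of this kind therefore holds for a different pair of groups, here on an aromatic carbon para to a large group, and neither pair among the compounds shown goes against it. Methylsulfamoyl and methylcarbamoyl both keep a methyl on nitrogen and have the same count of hydrogen-bond donors, differing in heavy atoms and hydrogen-bond acceptors, yet the step still lies beyond the scatter, though no measurement shown explains this drop.

As far as these compounds go, two pairs are a small base, so it remains open how far the direction extends to other groups on this carbon, such as a carboxylic acid, an amine or a nitrile. From the compounds shown here alone, it is also open how the number would respond to a longer chain on the amide nitrogen, such as ethyl or propyl in place of methyl, or to a ring there.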